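Extending the Chain to the Tetrazolyl Group

A few compounds are considered here, and "the series" means these few. Any claim that something is new, unique, unknown or untested is made for them only; others in the source may bear on it.

Compound 1 `CCCc1c(COc2ccc(C(=O)CCc3nnn[nH]3)cc2)ccc(C(C)=O)c1O` and compound 2 `CCCc1c(COc2ccc(C(=O)CCCCc3nnn[nH]3)cc2)ccc(C(C)=O)c1O` share one core and differ only in the tether to the tetrazolyl ring. In a functional assay on ileum (Cavia porcellus) with cysteinyl leukotriene receptor (Homo sapiens) as the target (on this read-out lower numbers stand for lower potency and higher numbers for higher potency (the scale is a negative logarithm)), compound 1 gives 7.09, and compound 2 gives 7.28, the two numbers lying within the scatter of each other, so compound 1 cannot be set apart from compound 2 on these data. Going by the values given here, the single step measured, a number 0.19 log units higher from compound 1 to compound 2 (within the scatter), stays within the scatter. Compound 3 `CCCc1c(COc2ccc(C(=O)CCCCCCc3nnn[nH]3)cc2)ccc(C(C)=O)c1O` carries the change (4-(1H-tetrazol-5-yl)butyl in place of 1H-tetrazol-5-yl on a saturated chain carbon, two bonds along the chain from a carbonyl carbon). Among the compounds with values here, this continues the same lengthening seen from compound 1 to compound 2, so the only step bearing on it is a number 0.19 log units higher from compound 1 to compound 2 (within the scatter); as that step stayed within the scatter, no step beyond the scatter is expected for compound 3, with at most a slight rise. The estimate for compound 3 in this assay is 7.3, with an expected range from 6.7 to 7.9. This amounts to an expected step of a number 0.21 log units higher from compound 1 to compound 3 (within the scatter).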

Compound 3, negative logarithm of the antagonist equilibrium constant: 7.33
Compound 3: the middle estimate sits 0.03 log units below what was measured, and the stated range covers the measured number.
By their numbers in this assay, from the lowest: compounds 1, 2 and 3 (each within the scatter of the next).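

Putting 4-(1H-tetrazol-5-yl)butyl in place of 1H-tetrazol-5-yl on a saturated chain carbon, two bonds along the chain from a carbonyl carbon, gives in this assay a number 0.24 log units higher from compound 1 to compound 3 (within the scatter), and the smaller change from 2-(1H-tetrazol-5-yl)ethyl gives a number 0.05 log units higher from compound 2 to compound 3 (within the scatter). This place therefore takes a group of 9 heavy atoms in place of one of 5 with no step beyond the scatter, which the earlier pair had shown only for the shorter tether. Nothing available here accounts for this result.

The compounds shown leave open whether a longer chain than 4-(1H-tetrazol-5-yl)butyl would also stay within the scatter. They also leave open how a carboxylic acid in place of the 1H-tetrazol-5-yl group would read in this assay.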